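The source may hold more compounds than are shown below. What is called first, only, known or untested is meant among the compounds shown, and "the series" means these compounds.

Among the compounds with values here, in a functional assay on K562 cells (Homo sapiens) for cytotoxicity, read by trypan blue exclusion, with a stated time of 96 h (on this read-out higher numbers stand for weaker inhibition and lower numbers for stronger inhibition), compound 2 (`COc1cc(OC)c(/C=C/S(=O)(=O)Cc2ccc(OC)c(NCCC(=O)O)c2)c(OC)c1`) gives 5000 nM as the highest of the two numbers so far, while compound 1 (`COC(=O)C(C)(C)Nc1cc(CS(=O)(=O)/C=C/c2c(OC)cc(OC)cc2OC)ccc1OC`) gives 800 nM and so inhibits more strongly. Compound 3 (`COc1cc(OC)c(/C=C/S(=O)(=O)Cc2ccc(OC)c(NC(C)(C)C(=O)O)c2)c(OC)c1`) differs from compound 2 in one place (1-carboxy-1-methylethyl in place of 2-carboxyethyl on a nitrogen on an aromatic ring): 1-carboxy-1-methylethyl in place of 2-carboxyethyl on a nitrogen on an aromatic ring. Within the data shown here, one measured step bears on this (a 6.3-fold higher number from compound 1 to compound 2 (0.80 log units; beyond the scatter)). It was modest but beyond the scatter, and it brought in 2-carboxyethyl in place of 1-(methoxycarbonyl)-1-methylethyl. Compound 3 keeps the carboxy group of compound 2 and shares only the 1-methylethyl part with compound 1 (800 nM), so it should recover only part of that step. A small step to a lower number in this assay is therefore expected (a 1.7-fold lower number from compound 2 to compound 3 (0.22 log units; within the scatter)) and it may stay within the scatter. Compound 3 is estimated at 3000 nM with 900 nM to 10000 nM as the expected range.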

Compound 3, half-maximal inhibitory concentration: 7.5 nM
Compound 3: the middle estimate sits 400-fold (2.60 log units) above what was measured, outside the stated range (below it).
By their numbers in this assay, from the lowest: compound 3; then compound 1; then compound 2.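

In this assay, exchanging 2-carboxyethyl for 1-carboxy-1-methylethyl on the nitrogen gives a 670-fold lower number from compound 2 to compound 3 (2.82 log units; beyond the scatter) and shows that a carboxy group at this position is not weak in itself: the result depends heavily on the chain that carries it. Within the data shown here, removing the methyl of the ester gives a 110-fold lower number from compound 1 to compound 3 (2.03 log units; beyond the scatter) and shows that, on this branched chain, the free carboxylic acid is far stronger than its methyl ester, which the earlier compounds could not show. Nothing available explains why so small a change has so large an effect.

Going by these compounds, it remains open whether a single methyl, as in a 1-carboxyethyl group, would be enough or whether both methyls are needed. On these data alone, it is also open whether a primary amide in place of the carboxylic acid would keep this strength on the same branched chain.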